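The source may report more compounds than this note shows. Statements on the series, on what has been measured and on what is new or still open speak of the compounds shown alone.

Two compounds with a shared core have been examined in a functional assay on PC-3 cells (Homo sapiens) for inhibition, read by sulforhodamine B assay, with a stated time of 48 h, tested at 50 uM; a lower number here means less inhibition of growth, a higher number more inhibition of growth at the concentration tested. In this assay compound 1 (`COc1ccccc1/C=C/C(=O)/C=C/c1ccc(OCc2cn(CCCCOc3cc(=O)oc4ccccc34)nn2)c(OC)c1`) is reported as "not active" (no number reported). For the measured compounds named here, compound 2 (`COc1cc(/C=C/C(=O)/C=C/c2cc(OC)c(OC)c(OC)c2)ccc1OCc1cn(CCCCOc2cc(=O)oc3ccccc23)nn1`) gives 5%, the only number available, and it therefore has no other number to be ranked against. The next compound to be tested is compound 3 (`COc1cc(/C=C/C(=O)/C=C/c2cccs2)ccc1OCc1cn(CCCCOc2cc(=O)oc3ccccc23)nn1`), which differs from compound 2 at one place: thiophen-2-yl in place of 3,4,5-trimethoxyphenyl on a double-bonded chain carbon bound to a double-bonded chain carbon. Its thiophen-2-yl stands in place of the 3,4,5-trimethoxyphenyl on a double-bonded chain carbon bound to a double-bonded chain carbon.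

Going by the values given here, no two measured compounds differ in one place alone, and no measured step is available as a guide. The expectation rests on compound 2 at 5% and on compound 1 at "not active" (no number reported), neither of which shows much inhibition of growth. In this assay, no step beyond the usual scatter is expected, and no firm direction can be given. The estimated change is a number 3 percentage points higher from compound 2 to compound 3 (within the scatter). For compound 3 the expected value is 8%, with an estimated range of 0% to 25%.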

Compound 3, percent growth inhibition at one concentration: "not active" (no number reported)
The entry for compound 3 holds no number, so the estimate cannot be set against anything.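

For the compounds shown here, with no number for compound 3 in this assay no step from compound 2 to compound 3 can be read. Nothing measured here offers an explanation for this result. The compounds shown leave open whether any group at this place on the shared core would give clear inhibition of growth in this assay.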